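Swapping the sulfanyl link for a benzylamine on the core

The source may hold more compounds than are shown below. What is called first, only, known or untested is meant among the compounds shown, and "the series" means these compounds.

Three compounds share one fused core carrying a phenyl group and two amino groups and differ in the substituent on the aromatic carbon next to the ring nitrogen. Compound 1 `CCOC(=O)[C@H](CCC(=O)O)NC(=O)c1ccc(Sc2nc3cc(N)cc(N)c3nc2-c2ccccc2)cc1` bears an arylsulfanyl arm ending in a glutamate-derived ester. Compound 2 `Nc1cc(N)c2nc(-c3ccccc3)c(Sc3ccc(F)cc3)nc2c1` carries a (4-fluorophenyl)sulfanyl group. Compound 3 `COc1cc(CNc2nc3cc(N)cc(N)c3nc2-c2ccccc2)cc(OC)c1OC` carries a trimethoxybenzylamino group. In a functional assay on DU-145 cells (Homo sapiens) for inhibition, read by sulforhodamine B assay, with a stated time of 48 h (a higher number here means a weaker inhibitor of growth, a lower number a stronger inhibitor of growth), compound 1 gives < 100000 nM, which is a limit of the assay and not a number. In this assay compound 2 gives < 100000 nM, again a limit rather than a number. In this assay compound 3 gives 20000 nM. Compound 2 therefore stands at the limit of < 100000 nM in this assay, at which 2 of the 3 values shown sit, and only compound 3 supplies a number.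

Compound 4 `Nc1cc(N)c2nc(-c3ccccc3)c(NCc3ccc(F)cc3)nc2c1` differs from compound 2 by a single change: (4-fluorobenzyl)amino in place of (4-fluorophenyl)sulfanyl on an aromatic carbon. Going by the values given here, no measured pair differs in one place, so no measured step sets the scale for this exchange. The change is expected to move compound 4 toward stronger growth inhibition, with the expected step from compound 2 to compound 4 being a step that the limit leaves unreadable from compound 2 to compound 4, because compound 3 with a benzylamino group on the same core gives 20000 nM. Compound 4 is accordingly estimated at about 30000 nM, expected to lie between 8000 nM and 100000 nM.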

Compound 4, concentration for total growth inhibition: 3800 nM
Estimate against measurement, compound 4: 7.9-fold (0.90 log units) above; measured number below the stated range.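

No size can be read for the step from compound 2 to compound 4, because compound 2 is known only through a limit of the assay and not through a number: the limit of < 100000 nM in this assay, at which 2 of the 4 values shown sit.

The compounds shown leave open how far (4-fluorobenzyl)amino in place of (4-fluorophenyl)sulfanyl on the shared core shifts growth inhibition in this assay, as no pair differing in that one place has two numbers.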